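A few compounds are considered here, and "the series" means these few. Any claim that something is new, unique, unknown or untested is made for them only; others in the source may bear on it.

The measured compounds:
Compound 1, `NCCCCOc1ccc2c(=O)c(-c3ccc(O)cc3)coc2c1`, gives 250 nM in an assay (Cricetulus griseus) for inhibition of aldehyde dehydrogenase, mitochondrial (Homo sapiens); on this read-out higher numbers stand for weaker inhibition and lower numbers for stronger inhibition.
Compound 2, `CCCCCCC(Oc1ccc2c(=O)c(-c3ccc(O)cc3)coc2c1)C(=O)O`, gives 2000 nM in this assay.

Compound 1 has the lower of the two numbers in this assay, so it is the stronger inhibitor of the pair; compound 2 stands far enough above it that the gap is real and not scatter. Both share the same core and differ only in the chain attached to the oxygen on the aromatic ring.

Compound 3, `CCCCCCOc1ccc2c(=O)c(-c3ccc(O)cc3)coc2c1`, has not yet been measured. It is reached from compound 1 by a single change: ethyl in place of amino on a saturated chain carbon, four bonds along the chain from an oxygen on an aromatic ring. Among the compounds with values here, no pair of measured compounds shows exactly this kind of change, so there is no measured step to lean on. Within the data shown here, the only hint is that compound 2, which carries a longer and more elaborate chain than compound 1, is markedly weaker; a simple hydrocarbon chain may sit nearer to compound 1 than to compound 2.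

The expected step is therefore small, a 1.6-fold higher number from compound 1 to compound 3 (0.20 log units; within the scatter), and may fall within the usual scatter. Compound 3 is expected to give about 400 nM in this assay, with a likely range from 100 nM to 1600 nM.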

Compound 3, half-maximal inhibitory concentration: 1500 nM
The estimate for compound 3 lay 3.8-fold (0.57 log units) below the measured number; measured number inside the range.
By their numbers in this assay, from the lowest: compound 1; then compounds 3 and 2 (each within the scatter of the next).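

In this assay, replacing amino with ethyl on a saturated chain carbon, four bonds along the chain from an oxygen on an aromatic ring, gives a 6.0-fold higher number from compound 1 to compound 3 (0.78 log units; beyond the scatter) and so weakens inhibition. This shows that, on the shared core, inhibition is sensitive to what stands at this place on the chain, which the earlier pair could not show because its chains differ in more than one place. Within the data shown here, the single change bundles two differences, since the amino group leaves with its hydrogen-bond donor and acceptor while the ethyl group brings neither and also extends the chain, and nothing available here explains the loss.

Going by these compounds, it remains open whether the nitrogen or the chain length matters more: a methyl group or a hydroxyl group in place of the amino group would keep the chain the same length as in compound 1 while replacing the nitrogen. A longer amine, with the amino group carried further out on the chain, would test the same question from the other side.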